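Swapping a Methyl for a Phenyl on the Chain

The source may report more compounds than this note shows. Statements on the series, on what has been measured and on what is new or still open speak of the compounds shown alone.

Of the compounds shown here, three sharing one core have been measured in an ADME assay on HEp-2 cells (Homo sapiens) for cytotoxicity, read by MTT assay, with a stated time of 3 days; on this read-out higher numbers stand for lower toxicity in this test and lower numbers for higher toxicity in this test. Compound 1 `CC[C@@H](CCn1cncn1)c1ccc(C)cc1` gives 69.9 ug/mL. Compound 2 `CC[C@H](CCn1cncn1)c1ccc(OC)cc1` gives 153 ug/mL, and compound 3 `CC[C@@H](CCn1cncn1)c1ccc(OC)cc1` gives 146 ug/mL. Compound 3 thus stands with the second highest number of the three, close to compound 2 and apart from compound 1. Two steps connect these compounds: a 2.1-fold higher number from compound 1 to compound 3 (0.32 log units; beyond the scatter), and a 1.0-fold lower number from compound 2 to compound 3 (0.02 log units; within the scatter); that second step falls within the scatter, in keeping with the fact that compounds 2 and 3 differ only in the configuration as drawn. Compound 4 `COc1ccc([C@H](CCn2cncn2)Cc2ccccc2)cc1` is the next compound; it differs from compound 3 in one place: phenyl in place of methyl on a saturated chain carbon, two bonds along the chain from an aromatic carbon. Neither measured step touches that part of the molecule: one changed a group on the aromatic ring, the other only the configuration as drawn, so neither gives a direct guide to the size or direction of this change. The expectation is therefore a step no larger than the scatter, a 1.3-fold lower number from compound 3 to compound 4 (0.12 log units; within the scatter), with wide bounds. Compound 4 is expected to give about 110 ug/mL, between 55 ug/mL and 220 ug/mL, in this assay.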

Compound 4, half-maximal cytotoxic concentration: 60.3 ug/mL
Estimate against measurement, compound 4: 1.8-fold (0.26 log units) above, within the range that was stated.
By their numbers in this assay, from the lowest: compounds 4 and 1 (each within the scatter of the next); then compounds 3 and 2 (each within the scatter of the next).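

In this assay, this saturated chain carbon proves to be a place where a change counts: phenyl in place of methyl gives a 2.4-fold lower number from compound 3 to compound 4 (0.38 log units; beyond the scatter), and here the lower number stands for higher toxicity in this test. Within the data shown here, the earlier steps touched only a group on the aromatic ring and the configuration as drawn, so this is the first sign that the chain also bears on the read-out, though it rests on one pair of compounds. Nothing at hand explains why this swap moves the number.

On these data alone, whether any larger group at this place would do the same, or whether the aromatic ring of phenyl matters, stays open, since a cyclohexyl or a propyl group there would be needed to tell these apart. Also open, as far as these compounds go, is whether the swap would act alike with methyl in place of methoxy on the aromatic ring, as in compound 1.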